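The source may report more compounds than this note shows. Statements on the series, on what has been measured and on what is new or still open speak of the compounds shown alone.

Measured so far:
compound 1 `COc1ccc(-c2cc(-c3cc(C(C)C)c(O)cc3C)[nH]c(=O)c2C#N)c(OC)c1` — 55%
compound 2 `COc1cc(OC)c(-c2cc(-c3cc(C(C)C)c(O)cc3C)[nH]c(=O)c2C#N)c(OC)c1` — 79%

Both readings come from a functional assay for inhibition, tested at 80 ug/mL; on this read-out higher numbers stand for a stronger effect at the one concentration tested and lower numbers for a weaker effect. Compound 1 stands lowest of the two numbers; the nearest is compound 2, and the step of a number 24 percentage points higher from compound 1 to compound 2 (beyond the scatter) lies beyond the scatter, so among these two the extra methoxy group goes with a stronger read-out.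

Compound 3 `Cc1cc(O)c(C(C)C)cc1-c1cc(-c2ccccc2[N+](=O)[O-])c(C#N)c(=O)[nH]1` is not yet measured. Against compound 1 the change is 2-nitrophenyl in place of 2,4-dimethoxyphenyl on an aromatic carbon. For the measured compounds named here, the single measured step bears only indirectly on it: it shows that adding a methoxy group to the 2,4-dimethoxyphenyl raises the number, whereas here the 2,4-dimethoxyphenyl leaves altogether and a 2-nitrophenyl enters. Going by the values given here, no step for a nitro group exists. On the loss of both methoxy groups, a modest fall is expected, a number 10 percentage points lower from compound 1 to compound 3 (within the scatter), with wide uncertainty. The estimate for compound 3 is 45%, ranging from 20% to 70%.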

Compound 3, a percentage reported as inhibition, at one concentration (the size of the read-out at that concentration, not a potency): 35%
The estimate for compound 3 lay 10 percentage points above the measured number; low and high end bracket the measured number.
By their numbers in this assay, from the lowest: compound 3; then compound 1; then compound 2.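

On the aromatic carbon ortho to a cyano group, this assay now shows a downward step as well as an upward one: 2-nitrophenyl in place of 2,4-dimethoxyphenyl gives a number 20 percentage points lower from compound 1 to compound 3 (beyond the scatter). The two groups have the same counts of hydrogen-bond donors and acceptors, so the step arises with no difference in those counts. No measurement bears on the origin of this step.

The change removes both methoxy groups and introduces the nitro group in a single step, so the compounds shown leave open which of these parts goes with the lower number. Also open, on these data alone, is how a plain phenyl or a 2-aminophenyl at this position would read, which could help separate the two parts.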